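The source may report more compounds than this note shows. Statements on the series, on what has been measured and on what is new or still open speak of the compounds shown alone.

In a functional assay on PC-3 cells (Homo sapiens) for inhibition, read by sulforhodamine B assay, with a stated time of 48 h (on this read-out higher numbers stand for weaker inhibition of growth and lower numbers for stronger inhibition of growth), compound 3 `COc1ccc(C(=O)/C=C/c2cc(-c3cc(OC)c(OC)c(OC)c3)n[nH]2)cc1OC` gives 2800 nM, the lowest of the two numbers shown. The nearest is compound 1 `COc1cc(-c2cc(/C=C/C(=O)c3ccc(N)cc3)[nH]n2)cc(OC)c1OC`, for which this assay gives 10400 nM, a gap told by a 3.7-fold lower number from compound 1 to compound 3 (0.57 log units; beyond the scatter). For compound 2 `COc1cc(-c2cc(/C=C/C(=O)c3ccc(Cl)c(Cl)c3)[nH]n2)cc(OC)c1OC` the same assay reports only a limit, > 100000 nM, and not a number. Compound 4 `COc1cc(-c2cc(/C=C/C(=O)c3ccc(F)c(F)c3)[nH]n2)cc(OC)c1OC` has not yet been measured; it differs from compound 3 by 3,4-difluorophenyl in place of 3,4-dimethoxyphenyl on a carbonyl carbon. For the measured compounds named here, two measured steps bear on this exchange at the carbonyl carbon. Replacing 4-aminophenyl with 3,4-dichlorophenyl gave an at least 9.6-fold higher number from compound 1 to compound 2 (0.98 log units; beyond the scatter), and the move from the dichlorinated ring to the dimethoxy ring gave an at least 35-fold lower number from compound 2 to compound 3 (1.55 log units; beyond the scatter). Compound 4 carries a 3,4-difluorophenyl, a dihalogenated ring like that of compound 2, and the move away from such a ring gave an at least 35-fold lower number from compound 2 to compound 3 (1.55 log units; beyond the scatter), so a step in the opposite direction, towards a higher number and beyond the scatter, is expected here. The expected step is a 14-fold higher number from compound 3 to compound 4 (1.15 log units; beyond the scatter). Compound 4 is therefore estimated at 40000 nM, with a range from 8000 nM to 200000 nM, and with a fair chance that this assay again reports only a limit rather than a number.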

Compound 4, concentration for total growth inhibition: 5720 nM
The estimate for compound 4 lay 7.0-fold (0.84 log units) above the measured number; the whole stated range lies above it.
By their numbers in this assay, from the lowest: compound 3; then compounds 4 and 1 (each within the scatter of the next). At a limit, above all of these: compound 2.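

Compound 4 shows that a dihalogenated ring on this carbonyl carbon need not sit at the far end of the series: in this assay the exchange of halogen gives an at least 17-fold lower number from compound 2 to compound 4 (1.24 log units; beyond the scatter) and so separates 3,4-difluorophenyl sharply from 3,4-dichlorophenyl. Leaving 3,4-dimethoxyphenyl costs far less, with a 2.0-fold higher number from compound 3 to compound 4 (0.31 log units; beyond the scatter) even though the entering ring has no hydrogen-bond acceptors, while a 1.8-fold lower number from compound 1 to compound 4 (0.26 log units; within the scatter) does not separate the 3,4-difluorophenyl ring from 4-aminophenyl. For compound 2 the reading is a limit and not a number: the limit of > 100000 nM in this assay, at which 1 of the 4 values shown sits.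

The compounds shown leave open whether a single fluorine, a single methoxy group or a trifluoromethyl on this ring would stay close to compound 4 or move towards compound 2. They also cannot tell why the two dihalogenated rings part so widely, or whether the same gap would appear on a core carrying something other than the trimethoxyphenyl group shared by these compounds.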